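Shifting a methoxy on the pendant phenyl of compound 3

A few compounds are considered here, and "the series" means these few. Any claim that something is new, unique, unknown or untested is made for them only; others in the source may bear on it.

Measured compounds:
compound 1 `COc1ccc(-c2cn3ccnc3c(-c3ccc4ncn(C5CCCCC5)c4c3)n2)cc1`: -12.3%
compound 2 `O=Cc1ccc(-c2cn3ccnc3c(-c3ccc4ncn(C5CCCCC5)c4c3)n2)cc1`: 11.2%
compound 3 `Brc1ccc(-c2cn3ccnc3c(-c3ccc4ncn(C5CCCCC5)c4c3)n2)cc1`: 20.7%

Of the compounds shown here, three sharing one core have been tested in a functional assay on A498 cells (Homo sapiens) for inhibition, read by sulforhodamine B assay, with a stated time of 48 h, tested at 10 uM; on this read-out lower numbers stand for less inhibition and higher numbers for more inhibition at the one concentration tested (going by the name of the read-out). Compound 1 gives -12.3%, compound 2 gives 11.2% and compound 3 gives 20.7%. Compound 3 has the highest of the three numbers, but its gap to compound 2 is within the scatter a number 9.5 percentage points higher from compound 2 to compound 3 (within the scatter), while the gap from compound 1 is clear a number 33 percentage points higher from compound 1 to compound 3 (beyond the scatter).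

Compound 4 `COc1ccccc1-c1cn2ccnc2c(-c2ccc3ncn(C4CCCCC4)c3c2)n1` is not yet measured. It differs from compound 3 in one place (2-methoxyphenyl in place of 4-bromophenyl on an aromatic carbon). The step that bears on this is the one from methoxy to bromo a number 33 percentage points higher from compound 1 to compound 3 (beyond the scatter), which was large; compound 4 runs the other way, although it does not repeat compound 1 exactly, since the entering group is 2-methoxyphenyl rather than the methoxyphenyl of compound 1. A fall beyond the scatter is therefore expected in this assay, estimated as a number 20.7 percentage points lower from compound 3 to compound 4 (beyond the scatter). Compound 4 is expected to give about 0%, within a range from -20% to 20%.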

Compound 4, a percentage reported as inhibition, at one concentration (the size of the read-out at that concentration, not a potency): 13.9%
Compound 4: middle estimate off by 13.9 percentage points, on the low side, and the stated range covers the measured number.
By their numbers in this assay, from the lowest: compound 1; then compounds 2, 4 and 3 (each within the scatter of the next).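

In this assay, the step between the 4-methoxyphenyl and the 2-methoxyphenyl keeps the same group on the phenyl and changes only where it sits, and it amounts to a number 26.2 percentage points higher from compound 1 to compound 4 (beyond the scatter), so the low number of compound 1 does not follow from a methoxy on this phenyl alone. The 2-methoxyphenyl also stands level with the other two aryl groups, as a number 6.8 percentage points lower from compound 3 to compound 4 (within the scatter) and a number 2.7 percentage points higher from compound 2 to compound 4 (within the scatter) are both small enough to leave these compounds unseparated. No measurement shown accounts for the effect of where the methoxy sits.

From the compounds shown here alone, it remains open whether bromo or formyl would behave the same way at the place the methoxy holds in the 2-methoxyphenyl. Going by these compounds, how an amine or a carboxylic acid on this phenyl would read in this assay is also open.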